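The compounds below may be only part of what the source reports. "The series", "measured", "known", "first", "only" and "open" are said of these compounds alone.

Compound 1 `COc1cccc(/C=C2\CCC/C(=C\c3cccc(Cl)c3)C2=O)c1OC`: 10300 nM
Compound 2 `COc1cccc(/C=C2\CCC/C(=C\c3ccc(Br)cc3)C2=O)c1OC`: 13700 nM

In a functional assay on HT-1080 cells (Homo sapiens) for cytotoxicity, read by MTT assay, with a stated time of 72 h (on this read-out lower numbers stand for stronger inhibition and higher numbers for weaker inhibition), compound 1 gives 10300 nM, the lowest of the two numbers, while compound 2 gives 13700 nM; the step of a 1.3-fold higher number from compound 1 to compound 2 (0.12 log units; within the scatter) lies within the scatter. Compound 3 `COc1cc(/C=C2\CCC/C(=C\c3cccc(OC)c3OC)C2=O)ccc1O` differs from compound 1 by 4-hydroxy-3-methoxyphenyl in place of 3-chlorophenyl on a double-bonded chain carbon bound to a double-bonded ring carbon. Within the data shown here, the only measured step exchanges one halogenated phenyl for another and left the number within the scatter, so it offers no direct guide for a hydroxy-methoxy substitution. Compound 3 is therefore expected to stay close to compound 1, with a step of a 1.0-fold lower number from compound 1 to compound 3 (0.01 log units; within the scatter) not beyond the scatter, giving an estimate of 10000 nM within 3500 nM to 30000 nM.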

Compound 3, half-maximal inhibitory concentration: 5900 nM
Compound 3: the middle estimate sits 1.7-fold (0.23 log units) above what was measured, within the range that was stated.
By their numbers in this assay, from the lowest: compounds 3, 1 and 2 (each within the scatter of the next, the first and the last beyond it).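

In this assay, among these compounds, the first non-halogen group at this place, 4-hydroxy-3-methoxyphenyl on a double-bonded chain carbon bound to a double-bonded ring carbon, gives a 1.7-fold lower number from compound 1 to compound 3 (0.24 log units; within the scatter) but a 2.3-fold lower number from compound 2 to compound 3 (0.37 log units; beyond the scatter) in the same comparison. The place therefore accepts a group bearing a hydrogen-bond donor without loss, and only the exchange for 4-bromophenyl moves the number beyond the scatter, modestly. No measurement here accounts for this step. The compounds shown leave open whether the hydroxy or the methoxy group carries the step. They also leave open how an amine or a carboxylic acid at this place would read.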